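Removing the methoxy: from compound 3 to compound 4

The source may report more compounds than this note shows. Statements on the series, on what has been measured and on what is new or still open speak of the compounds shown alone.

Measured so far in a functional assay on MCF7 cells (Homo sapiens) for antiproliferative activity; on this read-out higher numbers stand for weaker inhibition and lower numbers for stronger inhibition:
- compound 1, `C/C(=N\Nc1nc(-c2ccc(Cl)cc2)cs1)c1cc2ccccc2o1`: 29900 nM
- compound 2, `C/C(=N\Nc1nc(-c2ccc(C)cc2)cs1)c1cc2ccccc2o1`: 11100 nM
- compound 3, `COc1ccc(-c2csc(N/N=C(\C)c3cc4ccccc4o3)n2)cc1`: 18900 nM

Compound 3 sits second highest of the three numbers. Its closest neighbour is compound 1, and the two lie within the scatter of each other, as do compound 3 and compound 2, so no order among these three can be claimed, apart from the step from compound 1 to compound 2, which is beyond the scatter (a 2.7-fold lower number from compound 1 to compound 2 (0.43 log units; beyond the scatter)).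

Compound 4, `C/C(=N\Nc1nc(-c2ccccc2)cs1)c1cc2ccccc2o1`, differs from compound 3 by one change: hydrogen in place of methoxy on an aromatic carbon. Among the measured compounds shown here, no measured step removes a group at this position altogether; the measured steps only swap one group for another there, and two of them stay within the scatter (a 1.6-fold lower number from compound 1 to compound 3 (0.20 log units; within the scatter); a 1.7-fold higher number from compound 2 to compound 3 (0.23 log units; within the scatter)). On that basis compound 4 is expected to land close to compound 3, with a step of a 1.1-fold lower number from compound 3 to compound 4 (0.05 log units; within the scatter) in this assay, which is expected to be within the scatter. The estimate for compound 4 is 17000 nM, with a range from 7000 nM to 40000 nM.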

Compound 4, half-maximal inhibitory concentration: 8490 nM
Estimate against measurement, compound 4: 2.0-fold (0.30 log units) above; measured number inside the range.
By their numbers in this assay, from the lowest: compounds 4, 2, 3 and 1 (each within the scatter of the next, the first and the last beyond it).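

In this assay, taking the group away altogether counts for something: the bare phenyl gives a step beyond the scatter relative to the 4-methoxyphenyl (a 2.2-fold lower number from compound 3 to compound 4 (0.35 log units; beyond the scatter)), so this position needs no substituent to keep the activity seen so far. The same holds against chloro (a 3.5-fold lower number from compound 1 to compound 4 (0.55 log units; beyond the scatter)), whereas against methyl the step stays within the scatter (a 1.3-fold lower number from compound 2 to compound 4 (0.12 log units; within the scatter)), so hydrogen and methyl cannot be told apart here. Nothing available on these compounds explains these steps.

The compounds shown leave open what a group of a different kind at this position, such as an amine or a carboxylic acid, would do to the number. They also leave open whether a longer chain, such as butoxy in place of methoxy, would move it further from the value of compound 4.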